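Hydroxy for methoxymethyl on the open-chain analogue

A few compounds are considered here, and "the series" means these few. Any claim that something is new, unique, unknown or untested is made for them only; others in the source may bear on it.

Three compounds have been run in an ADME assay on CHO-K1 cells (Cricetulus griseus) for activation, read by fluorescence, tested at 1 uM; on this read-out higher numbers stand for a weaker effect at the one concentration tested and lower numbers for a stronger effect. Compound 1 `COc1cc(/C=C/C2=CC(=O)CC(c3ccc(O)c(OC)c3)N2CCCO)ccc1O` gives 91.8%, compound 2 `COCCCN1C(/C=C/c2ccc(O)cc2)=CC(=O)CC1c1ccc(O)cc1` gives 97.8%, and compound 3 `COCCCNC(=C\C(=O)/C=C/c1ccc(O)cc1)/C=C/c1ccc(O)cc1` gives 99.8%. The three numbers lie within the scatter of one another, so compound 3 holds the highest number without standing apart from the other two. Compound 4 `O=C(/C=C(/C=C/c1ccc(O)cc1)NCCO)/C=C/c1ccc(O)cc1` has not yet been measured in this assay. It differs from compound 3 in one place: hydroxy in place of methoxymethyl on a saturated chain carbon, two bonds along the chain from an amine nitrogen. Going by the values given here, no step between measured compounds sizes this change, and all measured numbers sit near the top of the read-out. The step from compound 3 to compound 4 is therefore expected to be a number 2.8 percentage points lower from compound 3 to compound 4 (within the scatter), nothing beyond the scatter. Compound 4 is expected to read 97%, between 88% and 104%.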

Compound 4, a percentage reported as activity, at one concentration (the size of the read-out at that concentration, not a potency): 93.4%
Beside the measured number, compound 4's estimate is 3.6 percentage points above it; measured number inside the range.
By their numbers in this assay, from the lowest: compounds 1, 4, 2 and 3 (each within the scatter of the next).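

In this assay, hydroxy in place of methoxymethyl on a saturated chain carbon, two bonds along the chain from an amine nitrogen, now has a measured size: a number 6.4 percentage points lower from compound 3 to compound 4 (within the scatter). Going by these compounds alone, this is the first one-place step, and the exchange of the hydrogen-bond acceptor-only group for a donor-bearing one leaves the open-chain analogue within the scatter. No supporting data bear on the reason for this result.

As far as these compounds go, it remains open whether a carboxylic acid or an amine at the end of the chain would move the number beyond the scatter. The same exchange on the core of compound 2 is also unresolved.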